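This account rests on a few compounds, and the source may have more. Where it says the series, first, only, none or still open, it means among the compounds named here.

Compound 2 `CCOC(=O)CCCCCOc1cccc(CN(C(=O)c2ccc(-c3cccc(OCC)c3)cc2)C(C)C)c1` is the reference point for the next step. In an ADME assay on HepG2 cells (Homo sapiens) for cytotoxicity, read by CellTiter-Glo and resazurin assay, with a stated time of 72 h (on this read-out lower numbers stand for an effect already at smaller amounts and higher numbers for an effect only at larger amounts of compound), compound 2 reaches only a limit, > 22300 nM. Going by the values given here, its one measured neighbour is compound 1 `CCOC(=O)CCCCCOc1cccc(CN(C(=O)c2ccc(-c3cccc4ccccc34)cc2)C(C)C)c1`. In this assay compound 1 likewise reaches only a limit, > 26000 nM. The step that the two limits leave unreadable from compound 1 to compound 2 therefore cannot be read, since both values sit at limits (the limit of > 22300 nM in this assay, at which 1 of the 2 values shown sits, and (the limit of > 26000 nM in this assay, at which 1 of the 2 values shown sits)), and compound 2 stands without a measured number.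

Compound 3 `CCOC(=O)CCCCCOc1cccc(CN(C(=O)c2ccc(-c3ccc4cc[nH]c4c3)cc2)C(C)C)c1` differs from compound 2 by 1H-indol-6-yl in place of 3-ethoxyphenyl on an aromatic carbon. Among the compounds with values here, no measured step bears directly on this exchange; the only known step, a step that the two limits leave unreadable from compound 1 to compound 2, is unreadable from its two limits. With compound 1 and compound 2 both at limits in this assay, the series gives no sign of cytotoxicity at the tested amounts. Compound 3 is expected to stay in the same region, with the estimated step that the limit leaves unreadable from compound 2 to compound 3 amounting to no change beyond the scatter. Compound 3 is accordingly estimated at 25000 nM, in the range 8000 nM to 80000 nM, most likely reported again as a limit.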

Compound 3, half-maximal effective concentration: > 26000 nM
Compound 3: no number, only a limit; the forecaster's own chance of this, stated with the estimate: 75%; middle value at least 1.0-fold (0.01 log units) away from the limit.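

The steps joining compound 3 to compound 1 and compound 2 cannot be read in this assay, because all three values are limits: the limit of > 26000 nM in this assay, at which 2 of the 3 values shown sit.

The compounds shown leave open at what concentration these compounds reach a half-maximal effect, and whether exchanging the aromatic group shifts it.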